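The compounds below may be only part of what the source reports. "The series", "measured", "known", "first", "only" and "open" are said of these compounds alone.

Compound 1 `CCCCc1ccc2c(c1)C(=O)C(=O)N2`: > 10000 nM
Compound 2 `COC(=O)/C=C/c1ccc2c(c1)C(=O)C(=O)N2Cc1ccc(C#N)cc1`: 80 nM
Compound 3 `COC(=O)/C=C/c1ccc2c(c1)C(=O)C(=O)N2Cc1ccc(C(F)(F)F)cc1`: 360 nM

All three values come from a functional assay on Jurkat cells (Homo sapiens) for antiproliferative activity, read by MTT assay, with a stated time of 48 h; on this read-out lower numbers stand for stronger inhibition and higher numbers for weaker inhibition. The entry for compound 1, > 10000 nM, is a limit of the assay and not a number. That leaves two real numbers to compare, and compound 2 holds the lower of them, 80 nM.

The next compound to be tested is compound 4 `COC(=O)/C=C/c1ccc2c(c1)C(=O)C(=O)N2Cc1cc(C)cc(C)c1`. It keeps the rest of compound 2 but carries 3,5-dimethylphenyl in place of 4-cyanophenyl on a saturated chain carbon bound to an amide-type nitrogen in a ring.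

For the measured compounds named here, only one measured step bears on this change: a 4.5-fold higher number from compound 2 to compound 3 (0.65 log units; beyond the scatter). There the nitrile was replaced and the number rose by a modest amount, beyond the scatter. Compound 4 loses the nitrile as well, though the group that replaces it is different, and a single step is thin support. A modest rise in this assay is therefore expected, of about the size seen for compound 3, with a wide margin on either side.

The estimate amounts to a 3.8-fold higher number from compound 2 to compound 4 (0.57 log units; beyond the scatter), an expected weakening. For compound 4 the expected value is 300 nM, with an estimated range from 100 nM to 1000 nM.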

Compound 4, half-maximal inhibitory concentration: 620 nM
For compound 4 the middle estimate is 2.1-fold (0.32 log units) below the measured one; low and high end bracket the measured number.
By their numbers in this assay, from the lowest: compound 2; then compounds 3 and 4 (each within the scatter of the next). At a limit, above all of these: compound 1.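

Replacing 4-cyanophenyl with 3,5-dimethylphenyl on the saturated chain carbon bound to an amide-type nitrogen in a ring gives a 7.8-fold higher number from compound 2 to compound 4 (0.89 log units; beyond the scatter) in this assay, so a second, different replacement of the nitrile-bearing group also raises the number. The step comes at an equal count of heavy atoms, and compound 2 keeps the lowest number of the compounds that carry a measured value here, while compound 3 and compound 4 lie within the usual scatter of each other and cannot be ranked. Nothing measured here explains why the number rises at this position.

Still open, as far as these compounds go, is whether the nitrile itself matters or whether other groups at this place would do as well, which a plain unsubstituted phenyl, a 4-methoxyphenyl or a 4-carboxyphenyl could help to show. The compounds with a measured number also all keep the same methyl ester chain, so a free carboxylic acid or an amide at that end remains an open question in this assay.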